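Swapping a Cyclopropyl Arm for an Ethoxy Group

The compounds below may be only part of what the source reports. "The series", "measured", "known", "first", "only" and "open" are said of these compounds alone.

Measured so far:
compound 1, `O=C(O)CCc1ccc(OCc2cccc(-c3ccncc3Cl)c2)s1`: 2010 nM
compound 2, `Cc1cccc(C)c1-c1cccc(COc2ccc(C(CC(=O)O)C3CC3)s2)c1`: 3920 nM

Both compounds were tested in a functional assay on cells for agonist activity at Free fatty acid receptor 1 (Homo sapiens), read by calcium flux; on this read-out lower numbers stand for an effect already at smaller amounts and higher numbers for an effect only at larger amounts of compound. Compound 2 shows the higher of the two numbers, but its value sits only a small distance from that of compound 1, and the two numbers fall within the usual scatter of repeated measurements, so they cannot be told apart on this read-out.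

Compound 3, `CCO[C@H](CC(=O)O)c1ccc(OCc2cccc(-c3c(C)cccc3C)c2)s1`, has not yet been measured. It is built from compound 2 by a single change: 2-carboxy-1-ethoxyethyl in place of 2-carboxy-1-cyclopropylethyl on an aromatic carbon. The carboxylic acid is kept, and the shared core and its large side group stay untouched.

Among the compounds with values here, no step between two measured compounds is known here, so nothing shows how this read-out responds to such a change. The expectation for the step of a 1.6-fold lower number from compound 2 to compound 3 (0.20 log units; within the scatter) is therefore a small move toward a lower number, one that may well stay within the scatter. Compound 3 is expected to give about 2500 nM in this assay, with a range from 600 nM to 10000 nM.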

Compound 3, half-maximal effective concentration: 50 nM
The estimate for compound 3 lay 50-fold (1.70 log units) above the measured number; measured number outside the range, below it.
By their numbers in this assay, from the lowest: compound 3; then compounds 1 and 2 (each within the scatter of the next).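

In this assay, the side chain on the aromatic carbon next to the ring sulfur turns out to matter far more than the first two compounds could show: 2-carboxy-1-ethoxyethyl in place of 2-carboxy-1-cyclopropylethyl gives a 78-fold lower number from compound 2 to compound 3 (1.89 log units; beyond the scatter), a large step well beyond the scatter. The two groups have the same count of heavy atoms and both carry the carboxylic acid, so this read-out can respond strongly to a swap that leaves both of those unchanged, one that removes the three-membered carbon ring and brings in an oxygen, a further hydrogen-bond acceptor and a defined stereocentre. Nothing measured here gives a reason for the size of this step, so which of those differences carries it stays unknown.

Still open, as far as these compounds go, is whether a methoxy group, or a longer chain such as propoxy, on the same carbon would give a number as low as that of compound 3, and whether a plain ethyl group, with carbon where the ether oxygen stands, would do the same. The compounds shown also leave open how the mirror-image form of compound 3 would behave in this assay.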